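The source may report more compounds than this note shows. Statements on the series, on what has been measured and on what is new or still open speak of the compounds shown alone.

In a functional assay on HT-29 cells (Homo sapiens) for inhibition, read by luminescence and CellTiter-Glo, with a stated time of 24 h (on this read-out higher numbers stand for an effect only at larger amounts of compound and lower numbers for an effect already at smaller amounts), three compounds sharing one core have been measured, differing only in the chain on an aromatic nitrogen. Compound 1 `CN1C(=S)[C@@H](NC(=O)c2nc(Cc3ccccc3)n(CCCO)n2)COc2ccccc21` gives 209 nM. Compound 2 `CN1C(=S)[C@@H](NC(=O)c2nc(Cc3ccccc3)n(CCCC#N)n2)COc2ccccc21` gives 2400 nM, and compound 3 `CN1C(=S)[C@@H](NC(=O)c2nc(Cc3ccccc3)n(CCCCCC#N)n2)COc2ccccc21` gives 3830 nM. The last two lie within the scatter of each other, and together they form the high end of the series, well above compound 1.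

The next change leads to compound 4 `CN1C(=S)[C@@H](NC(=O)c2nc(Cc3ccccc3)n(C3COC3)n2)COc2ccccc21`: oxetan-3-yl in place of 5-cyanopentyl on an aromatic nitrogen. Going by the values given here, no measured step covers this replacement, and no measured compound carries a ring at this nitrogen. The nearest evidence is an 18-fold higher number from compound 1 to compound 3 (1.26 log units; beyond the scatter) and an 11-fold higher number from compound 1 to compound 2 (1.06 log units; beyond the scatter), both large, while a 1.6-fold higher number from compound 2 to compound 3 (0.20 log units; within the scatter) stays within the scatter. The two nitrile chains therefore read alike. Among the compounds with values here, the change removes the nitrile, and compound 1, the only measured compound without one, gives 209 nM. A clear move towards a lower number is thus expected, though only part of the way to compound 1, as oxetan-3-yl is not a hydroxy chain. The step expected in this assay is a 4.3-fold lower number from compound 3 to compound 4 (0.63 log units; beyond the scatter). Compound 4 is estimated at 900 nM, with an expected range of 180 nM to 4000 nM.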

Compound 4, half-maximal effective concentration: 916 nM
For compound 4 the middle estimate is 1.0-fold (0.01 log units) below the measured one, within the range that was stated.
By their numbers in this assay, from the lowest: compound 1; then compound 4; then compounds 2 and 3 (each within the scatter of the next).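

In this assay, going by these compounds alone, the oxetan-3-yl ring gives the first reading for a ring on this aromatic nitrogen, and a 4.2-fold lower number from compound 3 to compound 4 (0.62 log units; beyond the scatter) and a 2.6-fold lower number from compound 2 to compound 4 (0.42 log units; beyond the scatter) set it apart from both nitrile chains by modest steps beyond the scatter. Leaving the nitrile out does not by itself bring the number down to that of the hydroxy chain, since a 4.4-fold higher number from compound 1 to compound 4 (0.64 log units; beyond the scatter) remains, so among these four compounds the position gives three separate levels: compound 1 lowest, compound 4 in the middle, and compounds 2 and 3 together at the high end. No supporting data are available to account for these gaps.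

The compounds shown leave open whether the step to compound 4 belongs to the four-membered ring or to its oxygen, which a cyclobutyl group on the same nitrogen would separate. They also leave open whether the low number of compound 1 depends on the hydroxy group itself, which 3-aminopropyl or 3-methoxypropyl at this nitrogen would test.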